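A few compounds are considered here, and "the series" means these few. Any claim that something is new, unique, unknown or untested is made for them only; others in the source may bear on it.

Measured compounds:
- compound 1 `Cc1cccc(Nc2nccc(-c3cc(C)oc3C)n2)c1` gives 28500 nM
- compound 2 `c1cc(Nc2nccc(-c3ccco3)n2)cc(-n2ccnc2)c1` gives 800 nM
- compound 3 `CCc1cccc(Nc2nccc(-c3ccco3)n2)c1` gives 9700 nM

All three were tested in a functional assay for inhibition, with Homo sapiens as the target; a lower number here means a stronger inhibitor, a higher number a weaker inhibitor. On these numbers compound 3 stands second highest of the three: compound 1 sits higher, and compound 2 sits well below it, the step of a 12-fold higher number from compound 2 to compound 3 (1.08 log units; beyond the scatter) being the largest difference among the measured compounds.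

Compound 4 `Cc1cccc(Nc2nccc(-c3ccco3)n2)c1` is the next compound on this path. It differs from compound 3 in one place: hydrogen in place of methyl on a saturated chain carbon bound to an aromatic carbon. The whole of the change is thus the loss of one carbon from a short side chain, with everything else left as it is.

For the measured compounds named here, none of the measured steps matches this change. Going by the values given here, the only single-place step available, from compound 2 to compound 3, swaps a whole ring-bearing group for the ethyl chain, a much larger alteration than trimming ethyl to methyl. Compound 1 carries a methyl in the same position as compound 4 but also a different furan, so its value shows only what a distant relative does. Among the compounds with values here, with no direct precedent, the shortening is expected to move this assay little, if at all, and compound 3 is taken as the anchor.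

Compound 4 is expected to give about 12000 nM, within a range from 4000 nM to 36000 nM, a step of a 1.2-fold higher number from compound 3 to compound 4 (0.09 log units; within the scatter) that is not expected to exceed the scatter.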

Compound 4, half-maximal inhibitory concentration: 2100 nM
For compound 4 the middle estimate is 5.7-fold (0.76 log units) above the measured one; measured number outside the range, below it.
By their numbers in this assay, from the lowest: compound 2; then compound 4; then compound 3; then compound 1.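

In this assay the trim from ethyl to methyl, on a saturated chain carbon bound to an aromatic carbon, proves to matter (a 4.6-fold lower number from compound 3 to compound 4 (0.66 log units; beyond the scatter)), so the loss of a single carbon at this place is enough to move the number beyond the scatter, and in the direction of a stronger inhibitor. The shorter chain still does not reach the 1H-imidazol-1-yl group (a 2.6-fold higher number from compound 2 to compound 4 (0.42 log units; beyond the scatter)), and the furan group now gets its first single-place reading, with furan-2-yl in place of 2,5-dimethylfuran-3-yl giving the largest of these new steps (a 14-fold lower number from compound 1 to compound 4 (1.13 log units; beyond the scatter)). Nothing shown here explains why any of these steps has the size it has.

Two chain lengths are too few to tell whether a longer chain such as propyl would raise the number further, or what an amine would do on the same aromatic carbon. The furan step also changes two things at once, the two methyl groups and the point of attachment, and a furan-3-yl group would be needed to tell these apart.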